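The source may report more compounds than this note shows. Statements on the series, on what has been measured and on what is new or still open speak of the compounds shown alone.

Of the compounds shown here, three have been measured in a functional assay on SK-MEL-5 cells (Homo sapiens) for inhibition, read by sulforhodamine B assay, with a stated time of 48 h, tested at 10 uM; on this read-out higher numbers stand for more inhibition of growth at the one concentration tested and lower numbers for less inhibition of growth. Compound 1 `COc1cc(-c2nc(N)n(CC(=O)Nc3ccc(/C(C)=N\O)cc3)n2)cc(OC)c1OC` gives 2.08%. Compound 2 `c1ccc(-c2nc3sc(-c4ccccc4)cn3n2)cc1` gives 20%. Compound 3 `COc1ccc(-c2nc3sc(-c4ccc(Cl)cc4)cn3n2)cc1` gives 27.5%, the largest of the three numbers shown, although the value of compound 2 lies within the usual scatter of it and only the value of compound 1 lies beyond that scatter.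

Compound 4 `Clc1ccc(-c2cn3nc(-c4ccccc4)nc3s2)cc1` has not yet been tested in this assay. It is made from compound 3 by one change: hydrogen in place of methoxy on an aromatic carbon. Among the compounds with values here, no pair of measured compounds differing in just one place is available, so the size of this step cannot be read off directly. Compound 2 lacks the same methoxy and also lacks the chlorine of compound 3, and its number sits within the scatter of that of compound 3, so for compound 4 no step beyond the scatter is expected in this assay. The step from compound 3 to compound 4 is estimated at a number 5.5 percentage points lower from compound 3 to compound 4 (within the scatter). Compound 4 is thus expected to give about 22%, within a range from 8% to 38%.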

Compound 4, percent growth inhibition at one concentration: 21%
Estimate against measurement, compound 4: 1 percentage points above, within the range that was stated.
By their numbers in this assay, from the lowest: compound 1; then compounds 2, 4 and 3 (each within the scatter of the next).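

In this assay, within the data shown here, hydrogen in place of methoxy on an aromatic carbon, para to a large group, gives a number 6.5 percentage points lower from compound 3 to compound 4 (within the scatter), the first step at this position that can be read directly. The methoxy group is therefore not shown to be needed for the growth inhibition seen at the one concentration tested, and the chloro change, read on its own as a number 1 percentage points higher from compound 2 to compound 4 (within the scatter), does not move the number beyond the scatter either. Nothing measured here offers a reason for the size of either step.

As far as these compounds go, whether an amine, a hydroxyl or a carboxylic acid at this position, or a longer chain such as butoxy, would give a step beyond the scatter remains open. Steps involving compound 1 cannot be read, since it differs from the other compounds in more than one place.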